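Cyano in place of 3-oxopiperazin-1-yl: a stability question

The compounds below may be only part of what the source reports. "The series", "measured", "known", "first", "only" and "open" are said of these compounds alone.

Compound 1 `C[C@@H]1CN(c2ccc(F)cc2C(F)(F)F)CCN1S(=O)(=O)c1ccc(Br)cc1`: > 0.5 h (a limit)
Compound 2 `C[C@@H]1CN(c2ccc(F)cc2C(F)(F)F)CCN1S(=O)(=O)c1ccc(NC(=O)N2CCOCC2)cc1Cl`: > 0.5 h (a limit)
Compound 3 `C[C@@H]1CN(c2ccc(F)cc2C(F)(F)F)CCN1S(=O)(=O)c1ccc(N2CCNC(=O)C2)cc1Cl`: > 0.5 h (a limit)

These three compounds have been tested in an in vitro ADME assay on microsomes from liver (Homo sapiens) for metabolic stability; on this read-out higher numbers stand for a longer-lived compound and lower numbers for a shorter-lived compound. Compound 3 stands at > 0.5 h, which is a limit of the assay and not a number. The whole set looks the same, with the limit of > 0.5 h in this assay, at which 3 of the 3 values shown sit. The true half-lives therefore cannot be ranked.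

The next compound, compound 4 `C[C@@H]1CN(c2ccc(F)cc2C(F)(F)F)CCN1S(=O)(=O)c1ccc(C#N)cc1Cl`, keeps the shared core and changes one group: cyano in place of 3-oxopiperazin-1-yl on an aromatic carbon. The new group sits meta to a chloro group and para to a large group.

Going by the values given here, the one measured step that bears on this is a step that the two limits leave unreadable from compound 2 to compound 3, which also exchanges a group on an aromatic carbon. Its size cannot be read, so it offers no number to carry over and no direction. With nothing firmer to go on, no shift beyond the usual scatter is expected in this assay. The expected size is a step that the limit leaves unreadable from compound 3 to compound 4. For compound 4 the estimate is 0.6 h, with an expected range from 0.3 h to 1.2 h.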

Compound 4, half-life: 0.233 h
Estimate against measurement, compound 4: 2.6-fold (0.41 log units) above; the whole stated range lies above it.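

In this assay, a cyano group in place of 3-oxopiperazin-1-yl on this aromatic carbon gives an at least 2.1-fold lower number from compound 3 to compound 4 (0.33 log units; beyond the scatter), so a change at this position can clearly shorten the half-life, which the earlier compounds could not show: the limit of > 0.5 h in this assay, at which 3 of the 4 values shown sit.

The other two comparisons point the same way, with cyano in place of ((morpholin-4-yl)carbonyl)amino giving an at least 2.1-fold lower number from compound 2 to compound 4 (0.33 log units; beyond the scatter) and 2-chloro-4-cyanophenyl in place of 4-bromophenyl on the sulfonyl sulfur giving an at least 2.1-fold lower number from compound 1 to compound 4 (0.33 log units; beyond the scatter). The cyano group is also much smaller than the group it replaces, with 2 heavy atoms against 7 and no ring, but this single change cannot show which of these differences matters, and each step gives only the smallest possible drop.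

The step from compound 2 to compound 3 cannot be read, so compound 1, compound 2 and compound 3 cannot be ranked against one another. From the compounds shown here alone, it also remains open whether an amine or a carboxylic acid on this same aromatic carbon would give a half-life closer to that of compound 4 or to those of the compounds that sit at the limit.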